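A few compounds are considered here, and "the series" means these few. Any claim that something is new, unique, unknown or untested is made for them only; others in the source may bear on it.

Measured in an assay on HEK293 cells for positive allosteric modulation of metabotropic glutamate receptor 3 (Rattus norvegicus), read by thallium flux, with a stated time of 2.5 min; on this read-out higher numbers stand for larger maximal responses and lower numbers for smaller maximal responses:

Compound 1 `Cc1c(OCCCCOc2ccccc2C(=O)O)ccc(C(=O)CC2CCCC2)c1C` gives 28%
Compound 2 `Cc1c(OCCCCOc2ccc(F)c(C(=O)O)c2)ccc(C(=O)CC2CCCC2)c1C` gives 12.6%

Compound 2 stands lowest of the two numbers, and its nearest neighbour is compound 1, which in this assay reaches 28%. Within the data shown here, the single measured step, a number 15.4 percentage points lower from compound 1 to compound 2 (beyond the scatter), was a modest loss that lies beyond the scatter; it combined a move of the carboxy group with the arrival of a fluoro, so it cannot be split cleanly into its two parts.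

Compound 3 `Cc1c(OCCCCOc2cccc(C(=O)O)c2)ccc(C(=O)CC2CCCC2)c1C` is not yet measured. Compared with compound 2 the change is hydrogen in place of fluoro on an aromatic carbon. Among the measured compounds shown here, no measured step isolates this change. For the measured compounds named here, the only guide is that compound 2, with the fluoro present, sits below compound 1, which has no fluoro, by a number 15.4 percentage points lower from compound 1 to compound 2 (beyond the scatter); removing the fluoro might therefore recover part of that gap, but the carboxy group keeps the position it has in compound 2, so a full return to the level of compound 1 is not expected.

For compound 3 the expected step is a number 6.4 percentage points higher from compound 2 to compound 3 (within the scatter), a small rise that may stay within the scatter. The estimate for compound 3 in this assay is 19%, expected between 8% and 32%.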

Compound 3, largest response reached (reported as percent of maximum), in percent of the reference or control that the assay uses: 16.5%
Compound 3: the middle estimate sits 2.5 percentage points above what was measured; low and high end bracket the measured number.
By their numbers in this assay, from the lowest: compounds 2 and 3 (each within the scatter of the next); then compound 1.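

In this assay, hydrogen in place of fluoro gives a number 3.9 percentage points higher from compound 2 to compound 3 (within the scatter) and so shows that on this aromatic carbon, ortho to a carboxy group, the fluoro makes no difference that can be told from the scatter. The earlier step mixed two changes, whereas compounds 1 and 3 differ in one place, and 3-carboxyphenyl in place of 2-carboxyphenyl gives a number 11.5 percentage points lower from compound 1 to compound 3 (beyond the scatter) with no fluoro involved; among these compounds, then, the lower maximal response goes with where the carboxy group sits and not with the fluoro. Nothing available here explains why the place of the carboxy group should matter.

On these data alone, whether a fluoro would have the same lack of effect on the 2-carboxyphenyl ring of compound 1 remains open, since the result for fluoro comes from the 3-carboxyphenyl series alone. Also open, as far as these compounds go, is whether a tetrazole or a primary amide could stand in for the carboxylic acid, and whether a chloro or a methoxy group would behave like the fluoro on this carbon.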